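Amide chain lengthening in a melatonin receptor series

The compounds below may be only part of what the source reports. "The series", "measured", "known", "first", "only" and "open" are said of these compounds alone.

Three compounds carry measurements in an assay for binding affinity to melatonin receptor (Gallus gallus); a lower number here means a stronger inhibitor, a higher number a weaker inhibitor. Compound 1 `COc1cccc(CNC(C)=O)c1` gives 57000 nM in this assay. Compound 2 `CCC(=O)NCc1cccc(OC)c1` gives 22000 nM in this assay. Compound 3 `CCC(=O)NCCCc1cccc(Br)c1` gives 318 nM in this assay, the lowest of the three numbers and beyond the scatter from both others.

For the measured compounds named here, the step of a 2.6-fold lower number from compound 1 to compound 2 (0.41 log units; beyond the scatter) is the one counted change among the measured pairs, (methyl in place of hydrogen on a saturated chain carbon bound to a carbonyl carbon). Compound 4 `CCCC(=O)NCCCc1cccc(Br)c1` has not been measured in this assay. It differs from compound 3 by methyl in place of hydrogen on a saturated chain carbon, two bonds along the chain from a carbonyl carbon. The two changes are of the same kind, a hydrogen giving way to a methyl on a saturated chain carbon, but the place is not the same: from compound 1 to compound 2 the carbon is bound to a carbonyl carbon, whereas from compound 3 to compound 4 it lies two bonds along the chain from a carbonyl carbon. The difference between the core of compound 1 and the core of compound 3 is not broken down here.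

Going by the values given here, the step from compound 3 to compound 4 in this assay is expected to be a 1.6-fold lower number from compound 3 to compound 4 (0.20 log units; within the scatter), set beside the measured 2.6-fold lower number from compound 1 to compound 2 (0.41 log units; beyond the scatter) but smaller, since the change is one bond further out and only one pair supports it. Compound 4 is estimated at 200 nM, within 80 nM to 600 nM.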

Compound 4, inhibition constant: 354 nM
Estimate against measurement, compound 4: 1.8-fold (0.25 log units) below, within the range that was stated.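

In this assay, the change from hydrogen to methyl on a saturated chain carbon does not carry over at one size from one core to the other: the same change on two cores in this assay, a 2.6-fold lower number (0.41 log units; beyond the scatter) from compound 1 to compound 2 and a 1.1-fold higher number (0.05 log units; within the scatter) from compound 3 to compound 4, 2.9-fold (0.46 log units) apart, beyond the scatter of two such steps

The new step, a 1.1-fold higher number from compound 3 to compound 4 (0.05 log units; within the scatter), lies within the scatter, so on this core the change from propanoyl to propylcarbonyl gives no readable shift in the number. This does not show that the core alone sets the outcome: the two steps differ in the core and also in the place of the methyl, bound to a carbonyl carbon in one and two bonds along the chain from a carbonyl carbon in the other, and with a single pair for each, the two influences cannot be separated, nor can any general rule for the series be drawn.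

Still open, from the compounds shown here alone, is whether a longer chain on the amide carbonyl, or a cyclopropyl group there, keeps the number as flat as propylcarbonyl does on the core of compound 3. Also open, going by these compounds, is what a methoxy group in place of the bromine would do on that same core, a single change that would begin to break down the difference between the two cores.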